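Cyclopentylamino for chloro on a second core: cytotoxicity

A few compounds are considered here, and "the series" means these few. Any claim that something is new, unique, unknown or untested is made for them only; others in the source may bear on it.

Compound 1, `COc1cccc(-c2nc3c(Cl)cccn3c2-c2ccnc(NC3CCCC3)n2)c1`: > 40000 nM
Compound 2, `COc1cccc(-c2nc3c(NC4CCCC4)cccn3c2-c2ccnc(NC3CCCC3)n2)c1`: > 40000 nM
Compound 3, `Fc1ccc(-c2nc3c(Cl)cc(Cl)cn3c2-c2ccnc(NC3CCCC3)n2)cc1`: > 40000 nM

In an ADME assay on Vero cells (Chlorocebus sabaeus) for cytotoxicity (on this read-out higher numbers stand for lower toxicity in this test and lower numbers for higher toxicity in this test), compound 1 reaches only the limit of the assay, > 40000 nM. Compound 2 likewise gives only a limit, > 40000 nM. The change between them is cyclopentylamino in place of chloro on an aromatic carbon, and the step that the two limits leave unreadable from compound 1 to compound 2 stays unreadable because of the limit of > 40000 nM in this assay, at which 3 of the 3 values shown sit.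

Compound 3 shows only a limit in this assay, > 40000 nM. Compound 4, `Fc1ccc(-c2nc3c(NC4CCCC4)cc(Cl)cn3c2-c2ccnc(NC3CCCC3)n2)cc1`, is not yet measured in this assay. Its change from compound 3 is the same kind of change as that from compound 1 to compound 2: cyclopentylamino in place of chloro on an aromatic carbon. Around the place, compound 4 differs in that the new group sits meta to a chloro group (1 heavy atom); the difference between the two cores is not broken down here. For compound 4 the expected step in this assay is a step that the limit leaves unreadable from compound 3 to compound 4, resting on compound 3 and its limit > 40000 nM and on the unreadable step from compound 1 to compound 2, so compound 4 is estimated at 45000 nM.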

Compound 4, half-maximal cytotoxic concentration: > 40000 nM
Compound 4 gave a limit, no number (the forecaster's own chance of this, stated with the estimate: 85%); the middle value is on the limit's open side.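

In this assay, going by these compounds alone, compound 4 gives only a limit, > 40000 nM, so no step from compound 3 to compound 4 can be read: the limit of > 40000 nM in this assay, at which 4 of the 4 values shown sit. The compounds shown leave open whether cyclopentylamino in place of chloro changes cytotoxicity on either core.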